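The source may hold more compounds than are shown below. What is called first, only, known or untested is meant among the compounds shown, and "the series" means these compounds.

In an assay on isolated protein (strain Sprague-Dawley) for inhibition of Amine oxidase [flavin-containing] A (Rattus norvegicus), read by spectrophotometry, with a stated time of 5 min, tested at 10 uM (on this read-out higher numbers stand for more inhibition at the one concentration tested (going by the name of the read-out) and lower numbers for less inhibition), compound 1 `CCOC(=O)Nc1cc(=O)oc2cc(OCc3cccc(Cl)c3)ccc12` gives 21% and compound 2 `O=Cc1cc(=O)oc2cc(OCc3cccc(Cl)c3)ccc12` gives 14%. For the measured compounds named here, the one measured step, a number 7 percentage points lower from compound 1 to compound 2 (within the scatter), puts formyl in place of (ethoxycarbonyl)amino on an aromatic carbon and stays within the usual scatter. Of the two numbers shown, compound 2 carries the lower one, but the gap to compound 1 is within the scatter and so marks no real difference between them. Compound 3 `CCOC(=O)c1cc(=O)oc2cc(OCc3cccc(Cl)c3)ccc12` differs from compound 2 by ethoxy in place of hydrogen on a carbonyl carbon; cut one bond further out, the same change reads formyl to ethoxycarbonyl. Going by the values given here, only that single step bears on this change, and it moved the number within the scatter, so a step of similar size is expected, a number 4 percentage points higher from compound 2 to compound 3 (within the scatter), with no direction beyond the scatter. Compound 3 is therefore estimated to give 18%, somewhere between 5% and 32%.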

Compound 3, a percentage reported as inhibition, at one concentration (the size of the read-out at that concentration, not a potency): 4.4%
Estimate against measurement, compound 3: 13.6 percentage points above; the measured number lies below the stated range.
By their numbers in this assay, from the lowest: compounds 3, 2 and 1 (each within the scatter of the next, the first and the last beyond it).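

For the compounds shown here, at this aromatic carbon, ethoxycarbonyl in place of (ethoxycarbonyl)amino gives a number 16.6 percentage points lower from compound 1 to compound 3 (beyond the scatter) in this assay and is the only step so far to pass the scatter, so the group attached here can change the reading, though modestly. Ethoxy in place of hydrogen on the carbonyl carbon gives a number 9.6 percentage points lower from compound 2 to compound 3 (within the scatter) and so does not separate the formyl compound from the ethoxycarbonyl compound. Nothing available explains why the step from the carbamate-bearing compound 1 to compound 3 passes the scatter.

Still open, going by these compounds, is how a carboxylic acid, a primary amine or a longer ester chain at this same carbon would read. On these data alone, each reading also comes from a single concentration, so it gives a size of inhibition and not a potency, and how these compounds compare in potency remains unknown.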